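This account rests on a few compounds, and the source may have more. Where it says the series, first, only, none or still open, it means among the compounds named here.

Measured in a functional assay on COLO 205 cells (Homo sapiens) for antiproliferative activity, read by WST assay, with a stated time of 3 days; on this read-out higher numbers stand for weaker inhibition and lower numbers for stronger inhibition:
- Compound 1 `[N-]=[N+]=Nc1cc(=O)[nH]c(=O)n1[C@@H]1O[C@H](CO)[C@@H](O)[C@H]1O`: > 50000 nM (a limit)
- Compound 2 `O=c1[nH]c(=O)n([C@@H]2O[C@H](CO)[C@@H](O)[C@H]2O)c(I)c1F`: > 50000 nM (a limit)

Compound 2 gives no number, only the limit > 50000 nM. Compound 1 also gives only a limit, > 50000 nM. Among the measured compounds shown here, both measured compounds therefore sit at the limit of > 50000 nM in this assay, at which 2 of the 2 values shown sit, and the series has no measured step yet.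

Compound 3 `[N-]=[N+]=Nc1c(F)c(=O)[nH]c(=O)n1[C@@H]1O[C@H](CO)[C@@H](O)[C@H]1O` has azido in place of iodo on an aromatic carbon, ortho to a fluoro group: azido in place of iodo on an aromatic carbon. It pairs the azido group of compound 1 with the fluoro group of compound 2.

No measured step sizes this change, so the expectation in this assay is loose: a modest move toward stronger inhibition, or no number at all. The expected step is an at least 2.5-fold lower number from compound 2 to compound 3 (0.39 log units; beyond the scatter). For compound 3 the estimated value is 20000 nM, with an expected range of 2000 nM to 60000 nM.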

Compound 3, half-maximal inhibitory concentration: 3800 nM
Estimate against measurement, compound 3: 5.3-fold (0.72 log units) above; measured number inside the range.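

In this assay, azido in place of iodo on the aromatic carbon next to the ring nitrogen gives an at least 13-fold lower number from compound 2 to compound 3 (1.11 log units; beyond the scatter), and fluoro in place of hydrogen on an aromatic carbon gives an at least 13-fold lower number from compound 1 to compound 3 (1.11 log units; beyond the scatter). Among the compounds shown here, compound 3 is the first with a measured number, and it carries the azido group and the fluoro group together, whereas compound 1 has azido without fluoro and compound 2 has fluoro with iodo. Both steps start from a limit, so each is bounded on one side only: the limit of > 50000 nM in this assay, at which 2 of the 3 values shown sit.

Open, on these data alone, is whether another group in the azido position, such as an amine or a methoxy group, would also give a measured number alongside the fluoro group. Also open, as far as these compounds go, is whether chloro in place of fluoro would keep the number of compound 3.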